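Three ureas at one solubility level, and a pyridine shift

A few compounds are considered here, and "the series" means these few. Any claim that something is new, unique, unknown or untested is made for them only; others in the source may bear on it.

The series rests on a diaryl urea core. Compound 1 `O=C(Nc1ccc(F)c(C(F)(F)F)c1)Nc1ccccn1` carries a pyridin-2-yl group on one urea nitrogen and a fluorinated, trifluoromethyl-bearing phenyl on the other. In a physicochemical assay for solubility, read by nephelometry, measured as kinetic solubility, at pH 2 (a lower number here means a less soluble compound, a higher number a more soluble compound), compound 1 gives 1.6 ug/mL. Compound 2 `NC(=O)c1ccccc1NC(=O)Nc1ccc(F)c(C(F)(F)F)c1` keeps the same fluorinated phenyl but replaces the pyridine by a benzene carrying a primary amide; in this assay compound 2 gives 1.6 ug/mL. Compound 3 `N#Cc1ccc(NC(=O)Nc2ccnc(C(F)(F)F)c2)cc1` moves the trifluoromethyl onto a pyridine and places a nitrile on the facing phenyl; in this assay compound 3 gives 1.6 ug/mL. On these numbers compound 1 stands level with compound 2 and compound 3, and none of the three separates from another beyond the scatter.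

Compound 4 `O=C(Nc1ccncc1)Nc1ccc(F)c(C(F)(F)F)c1` is compound 1 with its atoms joined differently: pyridin-4-yl in place of pyridin-2-yl on an amide-type nitrogen. Among the measured compounds shown here, no measured pair in this set differs in one place, so there is no measured step to lean on. Since all three measured compounds sit at one level, the step from compound 1 to compound 4 in this assay is expected to be small, a 1.9-fold higher number from compound 1 to compound 4 (0.27 log units; within the scatter), and not to exceed the scatter with confidence. Compound 4 is therefore estimated at 3 ug/mL in this assay, with a range from 1 ug/mL to 10 ug/mL.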

Compound 4, solubility: 6.3 ug/mL
For compound 4 the middle estimate is 2.1-fold (0.32 log units) below the measured one; the range from low to high includes it.
By their numbers in this assay, from the lowest: compounds 1, 2 and 3 (each within the scatter of the next); then compound 4.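

Among the compounds shown here, putting pyridin-4-yl in place of pyridin-2-yl on an amide-type nitrogen gives, in this assay, a 3.9-fold higher number from compound 1 to compound 4 (0.60 log units; beyond the scatter) and so provides the first step in this set between compounds that differ in one place, a modest one that lies beyond the scatter. Compounds 1, 2 and 3 could not show this, as they stand level and none of them forms such a pair; this position is now seen to respond to a change in how the pyridine is joined, with no atom added or removed and with the group counts printed for the two pyridinyl groups unchanged. Nothing measured here accounts for the step, which rests on this single pair.

The compounds shown leave open how pyridin-3-yl would read at this same amide-type nitrogen, and whether an amine or a carboxylic acid on the pyridine ring would carry the number further. They also leave open whether the same exchange of pyridin-2-yl for pyridin-4-yl would give a step of similar size on any core other than that of compound 1.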